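Replacing an Isopropyl Urea with an Aryl Urea

A few compounds are considered here, and "the series" means these few. Any claim that something is new, unique, unknown or untested is made for them only; others in the source may bear on it.

Three measured compounds frame the question. Compound 1 `CC(C)NC(=O)NC1CC(C)(C)Oc2ccc(Cl)cc21` is tested in a functional assay on U-373MG ATCC cells (Homo sapiens) for inhibition, read by MTT assay, with a stated time of 72 h (a lower number here means a stronger inhibitor, a higher number a weaker inhibitor), and gives 62000 nM. Compound 2 `CC1(C)CC(NC(=S)Nc2cccc(C#N)c2)c2cc(F)ccc2O1` gives 30000 nM in this assay, and compound 3 `COc1ccc(Cl)cc1CNC(=S)Nc1cccc([N+](=O)[O-])c1` gives 32000 nM in this assay. Among these three numbers compound 1 stands highest; the gap to compound 3 lies within the scatter of the measurement, so the two cannot be ordered, while the gap to compound 2 lies just beyond it, so compound 2 is the stronger inhibitor of that pair. No two of the measured compounds differ in only one place, so no single step can be read from them.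

Compound 4 `CC1(C)CC(NC(=O)Nc2ccccc2Cl)c2cc(Cl)ccc2O1` has not been measured in this assay. It differs from compound 1 in one place: 2-chlorophenyl in place of isopropyl on an amide-type nitrogen. The two measured compounds bearing an aromatic ring on the thiourea nitrogen, compound 2 and compound 3, both give lower numbers than compound 1, though their cores and linkers also differ from compound 4, so the comparison is loose. On that basis, a small step toward a stronger inhibitor is expected from compound 1 to compound 4 in this assay, of the size a 2.5-fold lower number from compound 1 to compound 4 (0.39 log units; beyond the scatter), and possibly within the scatter. For compound 4 the estimated value in this assay is 25000 nM, expected to fall between 7000 nM and 90000 nM.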

Compound 4, half-maximal inhibitory concentration: 17000 nM
Beside the measured number, compound 4's estimate is 1.5-fold (0.17 log units) above it; measured number inside the range.
By their numbers in this assay, from the lowest: compounds 4, 2, 3 and 1 (each within the scatter of the next, the first and the last beyond it).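

In this assay, putting 2-chlorophenyl in place of isopropyl on the amide-type nitrogen gives a 3.6-fold lower number from compound 1 to compound 4 (0.56 log units; beyond the scatter), a modest change but beyond the scatter. For the compounds shown here, this is the first reading of this position on an unchanged core, where the earlier compounds offered only a loose hint, and it shows that isopropyl is not needed there and that a larger aromatic ring is accepted with a lower number, although compound 4 still stands at 17000 nM. No accompanying measurement bears on why the number falls, so the step stands as an observation about this one change and nothing can be said about its origin.

From the compounds shown here alone, what remains open is whether the lower number follows from the aromatic ring itself or from its chlorine, a question that a plain phenyl group on the same nitrogen would address. Going by these compounds alone, it is also open how a cyclohexyl group, which has a ring but is not aromatic, or a pyridine ring in place of the 2-chlorophenyl would read in this assay, so the single step does not yet describe a trend at this position.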